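Swapping methyl for pyridin-3-ylmethyl on a piperazine nitrogen

This account rests on a few compounds, and the source may have more. Where it says the series, first, only, none or still open, it means among the compounds named here.

Three compounds sharing one core were tested in a functional assay on A-375 cells (Homo sapiens) for antiproliferative activity, read by CCK-8 assay, with a stated time of 72 h, tested at 8 uM; on this read-out higher numbers stand for a stronger effect at the one concentration tested and lower numbers for a weaker effect. Compound 3 `CN1CCN(C(=S)SCc2ccc(C(=O)Nc3ccccc3N)cc2)CC1` carries a methyl on an amine nitrogen in a ring and gives 91.6%, the highest of the three numbers. Compound 1 `Nc1ccccc1NC(=O)c1ccc(CSC(=S)N2CCN(Cc3ccccn3)CC2)cc1`, which bears a (pyridin-2-yl)methyl at that nitrogen, gives 82.4%; the step of a number 9.2 percentage points higher from compound 1 to compound 3 (within the scatter) is small. Compound 2 `Nc1ccccc1NC(=O)c1ccc(CSC(=S)N2CCN(c3ccc(Cl)cc3)CC2)cc1`, with a 4-chlorophenyl directly on that nitrogen, gives 29%, and the steps of a number 53.4 percentage points lower from compound 1 to compound 2 (beyond the scatter) and a number 62.6 percentage points higher from compound 2 to compound 3 (beyond the scatter) are large.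

Compound 4 `Nc1ccccc1NC(=O)c1ccc(CSC(=S)N2CCN(Cc3cccnc3)CC2)cc1` is not yet measured. It differs from compound 3 by pyridin-3-yl in place of hydrogen on a saturated chain carbon bound to an amine nitrogen in a ring; seen one bond further out, the change reads methyl to (pyridin-3-yl)methyl. The closest guide is compound 1, whose pyridin-2-yl analogue sits within the scatter of compound 3, as the step of a number 9.2 percentage points higher from compound 1 to compound 3 (within the scatter) shows; the large drop to compound 2 involves an aryl placed directly on the nitrogen, a different kind of change. For compound 4 a step of about a number 8.6 percentage points lower from compound 3 to compound 4 (within the scatter) is therefore expected, essentially none beyond the scatter. Compound 4 is estimated at 83%, within 62% to 95%.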

Compound 4, a percentage reported as inhibition, at one concentration (the size of the read-out at that concentration, not a potency): 89.2%
Beside the measured number, compound 4's estimate is 6.2 percentage points below it; the range from low to high includes it.
By their numbers in this assay, from the lowest: compound 2; then compounds 1, 4 and 3 (each within the scatter of the next).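

In this assay, a whole pyridin-3-yl ring can enter on this saturated chain carbon with only a number 2.4 percentage points lower from compound 3 to compound 4 (within the scatter), so this position accepts a far larger group than the methyl of compound 3 without a change that can be read. Moving the ring nitrogen makes no readable difference either: pyridin-3-yl in place of pyridin-2-yl gives a number 6.8 percentage points higher from compound 1 to compound 4 (within the scatter). The new compound also confirms the gap to the 4-chlorophenyl group, with a number 60.2 percentage points higher from compound 2 to compound 4 (beyond the scatter), leaving compound 2 as the only one of the four that stands apart.

No evidence is available that explains these numbers. Going by these compounds, it remains open whether a plain benzyl group or a longer chain such as 2-(pyridin-3-yl)ethyl would hold the effect, and whether a 4-chlorobenzyl group would show that compound 2 falls for its chlorine or for its ring sitting directly on the nitrogen.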